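The source may report more compounds than this note shows. Statements on the series, on what has been measured and on what is new or still open speak of the compounds shown alone.

Measured so far in an assay on cells for displacement of a labelled ligand from Glucagon receptor (Homo sapiens), in the presence of a further agent that is not named here; on this read-out higher numbers stand for weaker inhibition and lower numbers for stronger inhibition:

- compound 1, `CCCC(Nc1ccc(-n2cc(C(F)(F)F)cn2)nc1)c1ccc(C(=O)NCCC(=O)O)cc1`: 170 nM
- compound 2, `O=C(O)CCNC(=O)c1ccc(C(Oc2ccc(-n3cc(C(F)(F)F)cn3)cc2)C2CC2)cc1`: 1300 nM
- compound 3, `CCCC(Oc1ccc(-n2cc(C#N)cn2)cc1)c1ccc(C(=O)NCCC(=O)O)cc1`: 4100 nM

Compound 2 sits second highest of the three numbers in this assay. Its nearest neighbour is compound 3, whose value lies higher by a margin beyond the usual scatter; compound 1 is the furthest away, with a lower value, again beyond the scatter. So compound 2 is neither the tightest nor the loosest binder of the three, and the spread across the set is wide.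

Compound 4, `CC(C)CC(Oc1ccc(-n2cc(C(F)(F)F)cn2)cc1)c1ccc(C(=O)NCCC(=O)O)cc1`, has not been measured. It differs from compound 2 in one place: isobutyl in place of cyclopropyl on a saturated chain carbon bound to an aromatic carbon and an oxygen on an aromatic ring. For the measured compounds named here, no comparable step between two measured compounds exists in the set, so the size of this change has to be judged on the values alone. The isobutyl group is expected to be at least tolerated, and a modest improvement on compound 2 is anticipated; the step from compound 2 to compound 4 is estimated at a 2.2-fold lower number from compound 2 to compound 4 (0.34 log units; beyond the scatter), toward stronger inhibition. Compound 4 is thus expected to give about 600 nM in this assay, within a range of 200 nM to 2000 nM.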

Compound 4, inhibition constant: 549 nM
Compound 4: middle estimate off by 1.1-fold (0.04 log units), on the high side; the range from low to high includes it.
By their numbers in this assay, from the lowest: compound 1; then compound 4; then compound 2; then compound 3.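

In this assay, the saturated chain carbon bound to an aromatic carbon and an oxygen on an aromatic ring takes isobutyl in place of cyclopropyl, with a 2.4-fold lower number from compound 2 to compound 4 (0.37 log units; beyond the scatter) toward stronger inhibition. For the compounds shown here, this is the first single-place reading, and it shows that the three-membered ring is not required at this carbon: the open-chain group gives the lower number of the pair. Nothing measured here bears on why the number falls.

This single pair does not separate losing the ring from enlarging the group, and a cyclobutyl or a longer chain such as pentyl at this carbon would test that. Going by these compounds, compound 1 and compound 3 each differ from compound 4 in more than one place, so whether the step holds with their groups remains open.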